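From hydroxy to methoxy: compound 3 to compound 4

The compounds below may be only part of what the source reports. "The series", "measured", "known", "first", "only" and "open" are said of these compounds alone.

In a physicochemical assay for lipophilicity, at pH 7.4 (a lower number here means a more polar compound, a higher number a more lipophilic compound), compound 1 (`COc1cccc(C(=O)NCc2c(C)cc(C)[nH]c2=O)c1F`) gives 1.4, compound 2 (`COc1cccc(C(=O)NCc2c(C)cc(C)[nH]c2=O)c1Cl`) gives 1.2 and compound 3 (`COc1cccc(C(=O)NCc2c(C)cc(C)[nH]c2=O)c1O`) gives 1.9. Compound 3 has the highest number of the three, beyond the scatter from both of the others.

The next compound to be read is compound 4 (`COc1cccc(C(=O)NCc2c(C)cc(C)[nH]c2=O)c1OC`). Its difference from compound 3 is methyl in place of hydrogen on an oxygen on an aromatic ring, or hydroxy to methoxy.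

Among the measured compounds shown here, no measured step makes this exact change, so the evidence is indirect. The closest steps are those that introduce hydroxy, a number 0.50 log units higher from compound 1 to compound 3 (beyond the scatter) and a number 0.70 log units higher from compound 2 to compound 3 (beyond the scatter), both modest and beyond the scatter. The third step, a number 0.20 log units lower from compound 1 to compound 2 (within the scatter), stays within the scatter, so fluoro and chloro do not separate in this assay. Among these three compounds, only the one with hydroxy stands apart. For the measured compounds named here, compound 4 no longer carries that hydroxy, so its number is expected to return to the region of compound 1 at 1.4, though this rests on only three compounds.

A modest fall of similar size is therefore expected, an estimated a number 0.50 log units lower from compound 3 to compound 4 (beyond the scatter).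

For compound 4 the estimated value is 1.4, with an expected range from 1 to 1.8.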

Compound 4, distribution coefficient: 1.7
Compound 4: middle estimate off by 0.30 log units, on the low side, and the stated range covers the measured number.
By their numbers in this assay, from the lowest: compounds 2, 1, 4 and 3 (each within the scatter of the next, the first and the last beyond it).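

In this assay methyl in place of hydrogen on the oxygen reads as a number 0.20 log units lower from compound 3 to compound 4 (within the scatter) and the two compounds do not separate, so at this position the hydroxy and methoxy compounds stay together. Set against the two halogen compounds, methoxy reads as a number 0.30 log units higher from compound 1 to compound 4 (within the scatter) for fluoro and as a number 0.50 log units higher from compound 2 to compound 4 (beyond the scatter) for chloro and therefore sits apart only from the chloro compound. The gap that set compound 3 apart from both compound 1 and compound 2 thus does not carry over in full: the free hydrogen on that oxygen is not required for a separation from compound 2, while compound 4 no longer separates from compound 1.

Going by these compounds, how an amine, a carboxylic acid or a longer chain on that oxygen, such as ethoxy, would read at this position remains open, as does whether these small steps would hold on any other core. Nothing at hand bears on a cause for these steps, so the numbers stand here as description only.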